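A few compounds are considered here, and "the series" means these few. Any claim that something is new, unique, unknown or untested is made for them only; others in the source may bear on it.

Compound 1 `O=C(/C=C/c1ccccc1)OCC1COCCOCCOCCOCCOCCO1`; compound 2 `O=C(CCCCC1CCCCC1)OCC1COCCOCCOCCOCCOCCO1`.

Compound 1 is the ester with the 2-phenylethenyl group. In a functional assay on WiDr cells (Homo sapiens) for inhibition, read by sulforhodamine B assay, with a stated time of 48 h (a higher number here means a weaker inhibitor of growth, a lower number a stronger inhibitor of growth), compound 1 gives > 100000 nM, which is a limit of the assay and not a number. Compound 2 carries the 4-cyclohexylbutyl group on the carbonyl carbon, and in this assay compound 2 gives 33000 nM. Among the measured compounds shown here, this is the only number among the two values, the other being a limit (the limit of > 100000 nM in this assay, at which 1 of the 2 values shown sits). For the measured compounds named here, the step of an at least 3.0-fold lower number from compound 1 to compound 2 (0.48 log units; beyond the scatter) is the one measured comparison available.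

Compound 3 `CC(C)=CC1C(C(=O)OCC2COCCOCCOCCOCCOCCO2)C1(C)C` differs from compound 2 by 2,2-dimethyl-3-(2-methylprop-1-en-1-yl)cyclopropyl in place of 4-cyclohexylbutyl on a carbonyl carbon. Going by the values given here, the only measured step exchanges one carbon substituent on the carbonyl carbon for another and was at least modest in size; the change to compound 3 likewise replaces one saturated-ring carbon group with another carbon group bearing a three-membered ring. Among the compounds with values here, with no closer precedent, compound 3 is expected to stay near compound 2, the step of a 1.4-fold higher number from compound 2 to compound 3 (0.13 log units; within the scatter) expected to lie within or only slightly beyond the scatter. For compound 3 the estimate in this assay is 45000 nM, with a range from 12000 nM to 180000 nM.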

Compound 3, concentration for 50% growth inhibition: 56000 nM
For compound 3 the middle estimate is 1.2-fold (0.09 log units) below the measured one; measured number inside the range.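

In this assay, the exchange on the carbonyl carbon gives a 1.7-fold higher number from compound 2 to compound 3 (0.23 log units; within the scatter), so this place holds a group with a six-membered ring and one with a three-membered ring and a double bond, and the assay does not tell the two apart. The other new comparison is an at least 1.7-fold lower number from compound 1 to compound 3 (0.25 log units; that floor lies within the scatter), so compound 3, unlike compound 2, is not shown to differ from compound 1 beyond the scatter. Compound 1 stands at a limit of the assay, not a number: the limit of > 100000 nM in this assay, at which 1 of the 3 values shown sits.

The compounds shown leave open whether a carbon group is needed here at all, since an amine or a carboxylic acid at the end of the chain is not among them. They also leave open whether a plain longer alkyl chain with no ring would read the same as compound 2.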